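The compounds below may be only part of what the source reports. "The series", "measured", "known", "first", "only" and "open" are said of these compounds alone.

Working notes on the series in a functional assay on CHO cells for agonist activity at prostaglandin E2 receptor EP4 subtype (Rattus norvegicus), read by cAMP accumulation and immunoassay, with a stated time of 10 min; on this read-out higher numbers stand for an effect only at larger amounts of compound and lower numbers for an effect already at smaller amounts.

Of the compounds shown here, three have numbers so far. Compound 1 `O=C(O)CCCSCCN1C(=O)CC[C@@H]1/C=C/[C@@H](O)Cc1cccc(-c2cc3ccccc3o2)c1` gives 7 nM in this assay. Compound 2 `O=C(O)c1csc(SCCN2C(=O)CC[C@@H]2/C=C/[C@@H](O)Cc2cccc(-c3ccccc3)c2)n1` gives 8 nM. Compound 3 `O=C(O)c1csc(SCCN2C(=O)CC[C@@H]2/C=C/[C@@H](O)Cc2cccc(-c3ccc(Cl)cc3)c2)n1` gives 27 nM, the highest of the three numbers: the nearest is compound 2, and compound 1 lies furthest. For the measured compounds named here, the one single-point step so far is a 3.4-fold higher number from compound 2 to compound 3 (0.53 log units; beyond the scatter).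

The next compound, compound 4 `Cc1ccc2oc(-c3cccc(C[C@H](O)/C=C/[C@H]4CCC(=O)N4CCSc4nc(C(=O)O)cs4)c3)nc2c1`, differs from compound 3 by 5-methyl-1,3-benzoxazol-2-yl in place of 4-chlorophenyl on an aromatic carbon. Going by the values given here, no measured step exchanges a phenyl for a bicyclic heteroaryl at this position within the same acid chain, so the step from compound 2 to compound 3 bears only indirectly: it shows that adding a chloro on that phenyl raised the number beyond the scatter, so removing the chlorophenyl altogether could give back part of that. Compound 1 carries a related bicyclic heteroaryl at the same position and gives the lowest number of the three, but its acid chain differs from that of compound 3, so only its value, not a step, can be read.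

The expectation for compound 4 in this assay is therefore a 2.7-fold lower number from compound 3 to compound 4 (0.43 log units; beyond the scatter), putting it near compound 2. The estimate for compound 4 is 10 nM, with a range of 3 nM to 40 nM.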

Compound 4, half-maximal effective concentration: 8.8 nM
For compound 4 the middle estimate is 1.1-fold (0.06 log units) above the measured one; low and high end bracket the measured number.
By their numbers in this assay, from the lowest: compounds 1, 2 and 4 (each within the scatter of the next); then compound 3.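

In this assay, at the aromatic carbon of the six-membered ring, 5-methyl-1,3-benzoxazol-2-yl in place of 4-chlorophenyl gives a 3.1-fold lower number from compound 3 to compound 4 (0.49 log units; beyond the scatter), so the higher number of compound 3 does not extend to every larger group at this place. Against the plain phenyl, the same group gives a 1.1-fold higher number from compound 2 to compound 4 (0.04 log units; within the scatter), within the scatter: on this acid chain, a two-ring group that brings hydrogen-bond acceptors and a methyl stands level with phenyl, which has neither. The earlier compounds shown here showed a two-ring group here only in compound 1, on a different acid chain and with no step to read, whereas compounds 2, 3 and 4 now allow this exchange to be read directly on one chain.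

No measured evidence on the compounds gives a reason for these numbers, so the comparison remains descriptive. Open, from the compounds shown here alone, are what the methyl contributes relative to an unsubstituted 1,3-benzoxazol-2-yl, and whether the number of compound 3 is specific to chloro or would also appear with a methoxy or an amine on the phenyl.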